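The source may hold more compounds than are shown below. What is called first, only, known or untested is meant among the compounds shown, and "the series" means these compounds.

Measured so far in an ADME assay on THP-1 cells (Homo sapiens) for cytotoxicity, read by flow cytometry and propidium iodide staining, with a stated time of 48 h; on this read-out lower numbers stand for higher toxicity in this test and higher numbers for lower toxicity in this test:
- Compound 1 `O=[N+]([O-])c1cc(C(F)(F)F)cc([N+](=O)[O-])c1Nc1ccc(O)cc1`: 40000 nM
- Compound 2 `O=[N+]([O-])c1cc(C(F)(F)F)cc([N+](=O)[O-])c1Nc1ccccc1O`: > 50000 nM, a limit of the assay
- Compound 3 `O=[N+]([O-])c1cc(C(F)(F)F)cc([N+](=O)[O-])c1Nc1cccc(O)c1`: 35000 nM

Among the measured compounds shown here, compound 3 has one of only two actual numbers in the set, and it lies within the scatter of compound 1. The next analogue, compound 4 `O=[N+]([O-])c1cc(C(F)(F)F)cc([N+](=O)[O-])c1N1CCCCC1`, makes a larger change: piperidin-1-yl in place of (3-hydroxyphenyl)amino on an aromatic carbon.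

The measured steps only exchange one hydroxyphenyl group for another. They are an at least 1.2-fold higher number from compound 1 to compound 2 (0.09 log units; that floor lies within the scatter), a 1.1-fold lower number from compound 1 to compound 3 (0.06 log units; within the scatter) and an at least 1.4-fold lower number from compound 2 to compound 3 (0.15 log units; that floor lies within the scatter), and each lies within the scatter. None of them removes the hydroxyphenyl group or brings in piperidin-1-yl, so they give only weak guidance for this change. For the measured compounds named here, with flat steps as the sole precedent, no shift beyond the scatter is expected in this assay, although a move in either direction remains possible. The expected change is a 1.2-fold lower number from compound 3 to compound 4 (0.07 log units; within the scatter). The estimate for compound 4 is 30000 nM, with an expected range of 10000 nM to 50000 nM.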

Compound 4, half-maximal cytotoxic concentration: > 50000 nM
Compound 4: no number, only a limit; the forecaster's own chance of this, stated with the estimate: 35%; middle value at least 1.6-fold (0.22 log units) away from the limit.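

The aromatic carbon ortho to two nitro groups accepts more than an exchange of one hydroxyphenyl group for another: in this assay, piperidin-1-yl replaces the whole (hydroxyphenyl)amino group with no sign of higher toxicity in this test, giving an at least 1.4-fold higher number from compound 3 to compound 4 (0.15 log units; that floor lies within the scatter) and an at least 1.2-fold higher number from compound 1 to compound 4 (0.09 log units; that floor lies within the scatter). Neither the aromatic ring nor the hydroxyl of the departing group is therefore needed to keep toxicity this low, although both floors lie within the scatter and neither step alone shows a real rise in the number. Compound 4 gives a limit and not a number, and its step from compound 2 cannot be read: the limit of > 50000 nM in this assay, at which 2 of the 4 values shown sit.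

On these data alone, how far compound 4 actually lies from compound 1 and compound 3 stays open. A morpholin-4-yl group or an open-chain dialkylamine on the same carbon would test whether any amine there moves the number beyond the scatter.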